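Changing one group on a shared core

The compounds below may be only part of what the source reports. "The series", "measured", "known", "first", "only" and "open" are said of these compounds alone.

Three compounds that share one core have numbers in a functional assay on DU-145 cells (Homo sapiens) for cytotoxicity, read by MTT assay; on this read-out higher numbers stand for weaker inhibition and lower numbers for stronger inhibition. Compound 1 (`CCCC(CC(=O)O[C@H](CC=C(C)C)C1=CC(=O)c2c(O)ccc(O)c2C1=O)OC(C)=O`) gives 55700 nM, compound 2 (`CC(C)=CC[C@@H](OC(=O)C1CCOC1)C1=CC(=O)c2c(O)ccc(O)c2C1=O`) gives 47500 nM, and compound 3 (`CC(C)=CC[C@@H](OC(=O)C1CCCCO1)C1=CC(=O)c2c(O)ccc(O)c2C1=O`) gives 24700 nM. They differ only in the group on a carbonyl carbon. Compound 3 has the lowest number of the three, but that position is secure only against one neighbour: a 2.3-fold lower number from compound 1 to compound 3 (0.35 log units; beyond the scatter), whereas a 1.9-fold lower number from compound 2 to compound 3 (0.28 log units; within the scatter). The remaining pair shows a 1.2-fold lower number from compound 1 to compound 2 (0.07 log units; within the scatter).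

Compound 4 (`CC(C)=CC[C@@H](OC(=O)CC(C)(O)c1ccccc1)C1=CC(=O)c2c(O)ccc(O)c2C1=O`) has not yet been measured. It carries 2-hydroxy-2-phenylpropyl in place of oxan-2-yl on a carbonyl carbon. Within the data shown here, the three measured steps are the only guide, since they involve the same place, and all of them are small. Among the measured compounds shown here, none of the measured compounds has a six-membered aromatic ring of carbon only in this group, so the guide is imperfect and the direction stays open. The expected change is no step beyond the scatter, and the estimated step is a 1.2-fold higher number from compound 3 to compound 4 (0.08 log units; within the scatter). Compound 4 is therefore estimated at 30000 nM, with an expected range from 12000 nM to 70000 nM.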

Compound 4, half-maximal inhibitory concentration: > 100000 nM
Compound 4 ended at the assay's limit; the forecaster's own chance of this, stated with the estimate: 5%; middle value at least 3.3-fold (0.52 log units) from the limit.
By their numbers in this assay, from the lowest: compounds 3, 2 and 1 (each within the scatter of the next, the first and the last beyond it). At a limit, above all of these: compound 4.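

In this assay, compound 4 gives > 100000 nM, which is a limit of the assay and not a number. Even so, the group on this carbonyl carbon turns out to matter more than the three earlier compounds could show: 2-hydroxy-2-phenylpropyl, the first group here with a six-membered aromatic ring of carbon only, gives an at least 4.0-fold higher number from compound 3 to compound 4 (0.60 log units; beyond the scatter) and an at least 2.1-fold higher number from compound 2 to compound 4 (0.32 log units; beyond the scatter). The third comparison is less firm: an at least 1.7-fold higher number from compound 1 to compound 4 (0.25 log units; that floor lies within the scatter).

The compounds shown do not separate the aromatic ring from the hydroxyl group, which enter together in compound 4. As far as these compounds go, how a plain phenyl group or an amine on this carbonyl carbon would read stays open.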